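Swapping a fluorine for a chlorine on the aniline ring

The source may hold more compounds than are shown below. What is called first, only, known or untested is meant among the compounds shown, and "the series" means these compounds.

This series shares a common core carrying a substituted anilino group on one side and a bicyclic ether on the other. Compound 1 `Cc1c(Nc2ccc(C#N)cc2Cl)ncnc1OC1CC2COCC(C1)N2C(=O)OC(C)(C)C` was tested more than once in a functional assay on HEK293 cells for agonist activity at Glucose-dependent insulinotropic receptor (Mus musculus), read by fluorescence and cAMP accumulation, with a stated time of 30 min (a lower number here means that less compound is needed, a higher number that more compound is needed for the effect), and gives 280 nM; 100 nM (2 entries): the several entries of compound 1 in this assay, 280 nM; 100 nM (2 entries), so compound 1 has no single number to compare. Compound 2 `Cc1c(Nc2ccc(C#N)cc2Cl)ncnc1OC1C2COCC1CN(S(=O)(=O)C1CC1)C2` gives 844 nM in this assay. Compound 3 `COc1c(Nc2ccc(C#N)cc2F)ncnc1OC1C2COCC1CN(C(=O)OC1(C)CC1)C2` gives 47 nM in this assay, the lowest of the two single numbers, with compound 2 standing at a higher number by a gap that is beyond the usual scatter.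

Compound 4 `COc1c(Nc2ccc(C#N)cc2Cl)ncnc1OC1C2COCC1CN(C(=O)OC1(C)CC1)C2` differs from compound 3 in one place: chloro in place of fluoro on an aromatic carbon. Among the compounds with values here, compounds 1 and 2 already carry a chloro there, but they also differ from compound 3 elsewhere, so their values give no clean step for the chloro-for-fluoro change itself.

Within the data shown here, no measured step matches this change. The expectation is a small shift for compound 4, at most at the edge of the scatter, and if anything toward a higher number: the step of a 1.4-fold higher number from compound 3 to compound 4 (0.14 log units; within the scatter) is estimated. Compound 4 is therefore expected to give about 65 nM, with a likely range from 20 nM to 220 nM.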

Compound 4, half-maximal effective concentration: 43 nM
Estimate against measurement, compound 4: 1.5-fold (0.18 log units) above, within the range that was stated.
By their numbers in this assay, from the lowest: compounds 4 and 3 (each within the scatter of the next); then compound 2.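

Within the data shown here, the step, a 1.1-fold lower number from compound 3 to compound 4 (0.04 log units; within the scatter), is the first clean reading of this aromatic carbon on the aniline ring in this assay. Compounds 1 and 2 also carry the chloro, but their other differences from compound 3 hide what the halogen itself contributes. With the rest of the molecule held fixed, fluoro and chloro cannot be told apart here, so this spot accepts either halogen without a change beyond the scatter. The step is also small beside the distance that can separate repeat entries of one compound, a reminder not to read any order into this pair: the several entries of compound 1 in this assay, 280 nM; 100 nM (2 entries)

Among these compounds, whether the same exchange would be equally silent on a different background remains open, as compounds 1 and 2 have no fluoro partner to pair with, and a single pair cannot establish a general rule. It is also unknown how far the tolerance at this carbon extends to groups other than these two halogens, such as a plain hydrogen, an amine or a trifluoromethyl group.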